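The compounds below may be only part of what the source reports. "The series", "measured", "known", "first", "only" and "open" are said of these compounds alone.

Measured so far:
- compound 1, `Clc1ccc(C2=NN(c3ccccc3)C(c3cn(-c4ccccc4)nc3-c3ccc(Cl)c(Cl)c3)C2)cc1`: 53.4%
- compound 2, `O=[N+]([O-])c1ccc(N2N=C(c3ccc(Cl)cc3)CC2c2cn(-c3ccccc3)nc2-c2ccc(Cl)c(Cl)c2)cc1`: 57.3%

Both compounds were tested in a functional assay on the whole organism (strain Wistar) for inhibition, with Rattus norvegicus as the target, read by paw edema, with stated times of 30 min and 60 min, at a dose of 50 mg/kg by the oral route; on this read-out lower numbers stand for less inhibition and higher numbers for more inhibition at the one dose given (going by the name of the read-out). Compound 2 stands highest of the two numbers, with compound 1 nearest; the step of a number 3.9 percentage points higher from compound 1 to compound 2 (within the scatter) lies within the scatter, so the two values cannot be told apart.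

Compound 3, `CCC(=O)N1N=C(c2ccc(Cl)cc2)CC1c1cn(-c2ccccc2)nc1-c1ccc(Cl)c(Cl)c1`, has not yet been measured. It differs from compound 2 as follows: propanoyl in place of 4-nitrophenyl on an amine nitrogen in a ring. Going by the values given here, the only measured step, a number 3.9 percentage points higher from compound 1 to compound 2 (within the scatter), concerns a change on the aromatic ring and not on the amine nitrogen in the ring, so no measured step bears directly on this change. In the absence of any step at that place, the value of compound 2, 57.3%, is the only anchor, and no step beyond the scatter is expected for a number 5.3 percentage points lower from compound 2 to compound 3 (within the scatter).

Compound 3 is therefore estimated at 52%, with a range from 35% to 68%.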

Compound 3, a percentage reported as inhibition, in the whole organism at one dose (the size of the read-out at that dose, not a potency): 61.1%
Compound 3: middle estimate off by 9.1 percentage points, on the low side, and the stated range covers the measured number.
By their numbers in this assay, from the lowest: compounds 1, 2 and 3 (each within the scatter of the next).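

On the amine nitrogen in the ring, in this assay, propanoyl in place of 4-nitrophenyl gives a number 3.8 percentage points higher from compound 2 to compound 3 (within the scatter), and propanoyl in place of phenyl gives a number 7.7 percentage points higher from compound 1 to compound 3 (within the scatter). The earlier pair showed only a change on the aromatic ring carried by this nitrogen, whereas these steps show that the whole aromatic ring can give way to propanoyl, a group with no ring, without the number leaving the scatter. No other measurement is at hand to explain this result.

On these data alone, whether a longer chain such as hexanoyl, an amine or a carboxylic acid on this nitrogen would move the number beyond the scatter remains open. With a single dose and a single read-out, the compounds shown also leave potency open.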